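A Fluorine Added to a Benzyl Group

This account rests on a few compounds, and the source may have more. Where it says the series, first, only, none or still open, it means among the compounds named here.

Three compounds share one core, and all three sit at a limit in an assay on isolated protein for inhibition of DNA nucleotidylexotransferase (Homo sapiens), read by scintillation counting, with a stated time of 10 min; a higher number here means a weaker inhibitor, a lower number a stronger inhibitor. Compound 1 `C/C=C/n1cc(/C=C/C(=O)CC(=O)C(=O)OCC)c2ccccc21` gives > 40 uM, which is a limit of the assay and not a number. Compound 2 `CCOC(=O)C(=O)CC(=O)/C=C/c1cn(-c2ccc(O)cc2)c2ccccc12` gives > 40 uM, again a limit. Compound 3 `CCOC(=O)C(=O)CC(=O)/C=C/c1cc(C(=O)c2ccccc2)cn1Cc1ccccc1` gives > 40 uM, also a limit. Going by the values given here, the one single-point step in the set, a step that the two limits leave unreadable from compound 1 to compound 2, is left unreadable by the two limits. Compound 3 therefore stands where the other two stand, at the limit described by the limit of > 40 uM in this assay, at which 3 of the 3 values shown sit, with no number of its own.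

Compound 4 `CCOC(=O)C(=O)CC(=O)/C=C/c1cc(C(=O)c2ccccc2)cn1Cc1ccc(F)cc1` differs from compound 3 by fluoro in place of hydrogen on an aromatic carbon. Among the compounds with values here, no measured step in this set touches a benzyl group or a fluoro group; the one step that was measured changes a group on an aromatic nitrogen and cannot be sized. The account therefore expects no step beyond the scatter in this assay. The expected step is a step that the limit leaves unreadable from compound 3 to compound 4. Compound 4 is expected to give 60 uM, between 20 uM and 200 uM, and most likely to be reported once more as a limit rather than a number.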

Compound 4, concentration for 50% inhibition: > 40 uM
Compound 4: only a limit was reported; the forecaster's own chance of this, stated with the estimate: 85%; the middle value does not contradict the limit.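

In this assay compound 4 gives > 40 uM, a limit of the assay and not a number. Going by these compounds alone, compound 3 also sits at a limit, so no step between compound 3 and compound 4 can be read. The compounds shown leave open how strongly any of them inhibits, and what fluoro in place of hydrogen does to that inhibition: the limit of > 40 uM in this assay, at which 4 of the 4 values shown sit.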